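Pyridine in place of indole on the shared core

A few compounds are considered here, and "the series" means these few. Any claim that something is new, unique, unknown or untested is made for them only; others in the source may bear on it.

Of the compounds shown here, three built on one shared core have been measured in a functional assay on DU-145 cells (Homo sapiens) for antiproliferative activity, read by sulforhodamine B assay; a lower number here means a stronger inhibitor, a higher number a weaker inhibitor. Compound 1 `CCCCCCCCCCCCCCCCCCNC(=O)[C@H]1CSC(CCCCCCCCCCCC)N1` carries a dodecyl chain on a saturated ring carbon, and in this assay compound 1 gives 8900 nM. Compound 3 `CCCCCCCCCCCCCCCCCCNC(=O)[C@H]1CSC(c2c[nH]c3ccccc23)N1` carries 1H-indol-3-yl at that carbon; in this assay compound 3 gives 8900 nM, so it stands level with compound 1, and the step of no change at the digits printed from compound 1 to compound 3 (within the scatter). Compound 2 `CCCCCCCCCCCCCCCCCCNC(=O)[C@H]1CSC(C2CCCCC2)N1` carries cyclohexyl there, and in this assay compound 2 reaches only a limit of the assay, > 20000 nM. The one clear difference among the three is an at least 2.2-fold lower number from compound 2 to compound 3 (0.35 log units; beyond the scatter).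

Compound 4 `CCCCCCCCCCCCCCCCCCNC(=O)[C@H]1CSC(c2cccnc2)N1` has not been measured. It differs from compound 3 by pyridin-3-yl in place of 1H-indol-3-yl on a saturated ring carbon. Among the compounds with values here, two measured steps bear on this change: the move from the dodecyl chain to the indole, no change at the digits printed from compound 1 to compound 3 (within the scatter), and the move from cyclohexyl to the indole, an at least 2.2-fold lower number from compound 2 to compound 3 (0.35 log units; beyond the scatter). Within the data shown here, neither shows an aromatic group pushing the number far from where compound 1 sits, but no measured step yet tests a smaller aromatic ring. For compound 4 the expected value is 12000 nM, with a range from 5000 nM to 30000 nM. The expected step is a 1.3-fold higher number from compound 3 to compound 4 (0.13 log units; within the scatter).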

Compound 4, half-maximal inhibitory concentration: 7500 nM
Estimate against measurement, compound 4: 1.6-fold (0.20 log units) above; measured number inside the range.
By their numbers in this assay, from the lowest: compounds 4, 1 and 3 (each within the scatter of the next). At a limit, above all of these: compound 2.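

In this assay, replacing 1H-indol-3-yl with pyridin-3-yl on this saturated ring carbon removes the second aromatic ring and trades a hydrogen-bond donor for a hydrogen-bond acceptor, yet the outcome is a 1.2-fold lower number from compound 3 to compound 4 (0.07 log units; within the scatter). The single aromatic ring also sits level with the long chain, with a 1.2-fold lower number from compound 1 to compound 4 (0.07 log units; within the scatter), so three quite different groups at this position give matching numbers. Cyclohexyl alone stands apart among the four, with an at least 2.6-fold lower number from compound 2 to compound 4 (0.42 log units; beyond the scatter), and a second aromatic group now shows that gap.

From the compounds shown here alone, the true distance of compound 2 from the others stays open, since its number is only a limit: the limit of > 20000 nM in this assay, at which 1 of the 4 values shown sits. Whether a plain phenyl ring, which lacks the ring nitrogen, or an aromatic ring carrying an amine or a carboxylic acid would move the number also stays open.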